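The source may report more compounds than this note shows. Statements on the series, on what has been measured and on what is new or still open speak of the compounds shown alone.

Measured so far in a functional assay on 143B cells (Homo sapiens) for inhibition, read by MTT assay, with a stated time of 72 h; on this read-out lower numbers stand for stronger inhibition and higher numbers for weaker inhibition:

compound 1, `O=C(O)CCC(=O)OCCCCCCSc1ccc([N+](=O)[O-])c2nonc12`: 2830 nM
compound 2, `O=C(CCC(=O)OCCCCCCSc1ccc([N+](=O)[O-])c2nonc12)Nc1ccccc1`: 3850 nM
compound 3, `Cc1ccccc1NC(=O)CCC(=O)OCCCCCCSc1ccc([N+](=O)[O-])c2nonc12`: 4660 nM

Compound 1 holds the lowest of the three numbers in this assay, but the others lie close: the step of a 1.4-fold higher number from compound 1 to compound 2 (0.13 log units; within the scatter) and the step of a 1.6-fold higher number from compound 1 to compound 3 (0.22 log units; within the scatter) are both within the scatter, so no order among the three compounds can be claimed. Compound 4, `O=C(CCC(=O)OCCCCCCSc1ccc([N+](=O)[O-])c2nonc12)Nc1ccc(F)c(Cl)c1`, has not yet been measured. It differs from compound 1 in one place: (3-chloro-4-fluorophenyl)amino in place of hydroxy on a carbonyl carbon. Among the measured compounds shown here, the steps that bear on this change are those in which the hydroxy on the carbonyl carbon was likewise exchanged for anilino or (2-methylphenyl)amino, namely a 1.4-fold higher number from compound 1 to compound 2 (0.13 log units; within the scatter) and a 1.6-fold higher number from compound 1 to compound 3 (0.22 log units; within the scatter), together with a 1.2-fold higher number from compound 2 to compound 3 (0.08 log units; within the scatter), which alters only the ring that enters; none of them moved the number beyond the scatter. A step of about that size is therefore expected, if anything toward a slightly higher number: a 1.5-fold higher number from compound 1 to compound 4 (0.17 log units; within the scatter). Compound 4 is estimated to give 4200 nM in this assay, with a range from 2000 nM to 9000 nM.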

Compound 4, half-maximal inhibitory concentration: 2990 nM
For compound 4 the middle estimate is 1.4-fold (0.15 log units) above the measured one; the range from low to high includes it.
By their numbers in this assay, from the lowest: compounds 1, 4, 2 and 3 (each within the scatter of the next).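

In this assay, a ring carrying two halogens, entering on the carbonyl carbon in place of hydroxy, again stays within the scatter, with a 1.1-fold higher number from compound 1 to compound 4 (0.02 log units; within the scatter) as the step. Changing only the ring on the amide-type nitrogen also gives no readable difference: neither a 1.3-fold lower number from compound 2 to compound 4 (0.11 log units; within the scatter) nor a 1.6-fold lower number from compound 3 to compound 4 (0.19 log units; within the scatter) leaves the scatter, so 3-chloro-4-fluorophenyl cannot be told apart from phenyl or 2-methylphenyl here, and across these three rings no compound shown goes against this flat picture. Nothing available explains why these changes leave the number so little moved.

Going by these compounds, whether a saturated amine such as morpholine or piperidine on this carbonyl carbon would move the number beyond the scatter remains open. So does the outcome for a methyl ester at this place, or for a longer chain in the linker.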